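A Methyl Added on the Aromatic Ring of Compound 2

This account rests on a few compounds, and the source may have more. Where it says the series, first, only, none or still open, it means among the compounds named here.

Measured compounds:
compound 1 `Cc1ccc(S(=O)(=O)NC(=O)n2ccc3cccnc32)cc1`: 33.4%
compound 2 `CN(C)c1ccnc2c1ccn2C(=O)NS(=O)(=O)c1ccccc1`: 17.6%

In a functional assay on HT-29 cells (Homo sapiens) for antiproliferative activity, read by MTT assay, with a stated time of 24 h, tested at 10 uM (a higher number here means more inhibition at the concentration tested (going by the name of the read-out), a lower number less inhibition), compound 1 gives 33.4%. In this assay compound 2 gives 17.6%, the lowest of the two numbers, and its gap to compound 1 lies beyond the scatter. Compound 3 `Cc1ccc(S(=O)(=O)NC(=O)n2ccc3c(N(C)C)ccnc32)cc1` differs from compound 2 by methyl in place of hydrogen on an aromatic carbon. Within the data shown here, no measured pair shows this change, so no step size is known from the data. The step from compound 2 to compound 3 is expected to be small, estimated as a number 4.4 percentage points higher from compound 2 to compound 3 (within the scatter), with no clear direction beyond the scatter. Compound 3 is therefore expected near 22%, in a range from 8% to 38%.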

Compound 3, a percentage reported as inhibition, at one concentration (the size of the read-out at that concentration, not a potency): 21.5%
Compound 3: the middle estimate sits 0.5 percentage points above what was measured; the range from low to high includes it.
By their numbers in this assay, from the lowest: compounds 2 and 3 (each within the scatter of the next); then compound 1.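

In this assay, among these compounds, methyl in place of hydrogen on an aromatic carbon, para to a large group, gives a number 3.9 percentage points higher from compound 2 to compound 3 (within the scatter) and so is the first reading of this change at this position, with no shift that stands clear of the scatter. Bringing dimethylamino onto the core of compound 1 gives a number 11.9 percentage points lower from compound 1 to compound 3 (beyond the scatter) and is the first single-place change seen to lie beyond the scatter. Nothing shown gives a reason for either step. Still open, from the compounds shown here alone, is whether a methoxy group or a chlorine atom at this position would give a step beyond the scatter, and whether another amine in place of dimethylamino would give a similar step.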